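The source may report more compounds than this note shows. Statements on the series, on what has been measured and on what is new or still open speak of the compounds shown alone.

Measured in a functional assay for inhibition, with Homo sapiens as the target; on this read-out lower numbers stand for stronger inhibition and higher numbers for weaker inhibition:
- compound 1 `COC(=O)CCCCCCCCn1nc(-c2ccccc2)c(-c2ccccc2)c1-c1ccccc1`: 4300 nM
- compound 2 `O=C(O)CCCCCn1nc(-c2ccccc2)c(-c2ccccc2)c1-c1ccccc1`: > 78000 nM (a limit of the assay, not a number)
- compound 3 `O=C(O)CCCCCCCn1nc(-c2ccccc2)c(-c2ccccc2)c1-c1ccccc1`: 3400 nM

Going by the values given here, compound 3, at 3400 nM, holds one of only two true numbers in this small set. The other belongs to compound 1, and the step of a 1.3-fold lower number from compound 1 to compound 3 (0.10 log units; within the scatter) leaves the two within the scatter of each other.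

The next compound is compound 4 `O=C(O)CCCCCCCCn1nc(-c2ccccc2)c(-c2ccccc2)c1-c1ccccc1`, which differs from compound 3 as follows: carboxymethyl in place of carboxy on a saturated chain carbon, seven bonds along the chain from an aromatic nitrogen. In words, carboxymethyl stands in place of carboxy, on a saturated chain carbon, seven bonds along the chain from an aromatic nitrogen.

Among the compounds with values here, the closest precedent is the step of an at least 22-fold lower number from compound 2 to compound 3 (1.36 log units; beyond the scatter), where 2-carboxyethyl replaces carboxy among the acids. The step of an at least 18-fold higher number from compound 1 to compound 2 (1.25 log units; beyond the scatter) is of similar size, and both rest on the limit of compound 2, so they give a direction but no exact size. The step of a 1.3-fold lower number from compound 1 to compound 3 (0.10 log units; within the scatter) shows that compound 1 and compound 3 do not separate in this assay, which argues against another large change. A modest move towards a lower number is therefore expected, most likely without clearing the scatter.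

The expected step is a 1.4-fold lower number from compound 3 to compound 4 (0.13 log units; within the scatter). For compound 4 the estimate is 2500 nM, with an expected range of 800 nM to 8000 nM.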

Compound 4, half-maximal inhibitory concentration: 400 nM
Compound 4: middle estimate off by 6.3-fold (0.80 log units), on the high side; measured number below the stated range.
By their numbers in this assay, from the lowest: compound 4; then compounds 3 and 1 (each within the scatter of the next). At a limit, above all of these: compound 2.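

The step of an 8.5-fold lower number from compound 3 to compound 4 (0.93 log units; beyond the scatter) shows that a single extra chain carbon, with carboxymethyl in place of carboxy seven bonds along the chain from an aromatic nitrogen, still moves the number beyond the scatter, so the gain among the acids did not end at compound 3. Going by these compounds alone, the step of an 11-fold lower number from compound 1 to compound 4 (1.03 log units; beyond the scatter), hydrogen in place of methyl on an oxygen next to a carbonyl group, gives the only comparison here of the free acid and the methoxycarbonyl group on one unchanged chain, and it shows that this end group matters, which the match between compound 1 and compound 3 could not reveal. Compound 2 stands at a limit of the assay and not at a number, so the step of an at least 190-fold lower number from compound 2 to compound 4 (2.29 log units; beyond the scatter) gives a direction and a minimum size only: the limit of > 78000 nM in this assay, at which 1 of the 4 values shown sits.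

On these data alone, whether a longer chain bearing the carboxylic acid would lower the number further or raise it again remains open. As far as these compounds go, it is equally open whether an amide in place of the carboxylic acid on the chain of compound 4 would keep the number of that compound.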